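Chloro in Place of Hydrogen on Two Related Cores

A few compounds are considered here, and "the series" means these few. Any claim that something is new, unique, unknown or untested is made for them only; others in the source may bear on it.

Of the compounds shown here, three have been tested in a functional assay on HCT-116 cells (Homo sapiens) for antiproliferative activity, read by MTT assay, with a stated time of 48 h; a higher number here means a weaker inhibitor, a lower number a stronger inhibitor. Compound 1 `CCCCC(CCO)n1cnc2c(Cl)ncnc21` gives > 50000 nM, which is a limit of the assay rather than a number. Compound 2 `CCCCC(CCO)n1cnc2cncnc21` likewise gives > 50000 nM, again a limit. Among the compounds with values here, compound 3 `CCCCCCCCCC(CCO)n1cnc2c(N)ncnc21` in this assay gives 10500 nM, the only number among the three. The difference between the core of compound 3 and the core of compound 2 is not broken down here. The change from compound 2 to compound 1 is chloro in place of hydrogen on an aromatic carbon, and its step, a step that the two limits leave unreadable from compound 2 to compound 1, cannot be read because both values sit at the limit of > 50000 nM in this assay, at which 2 of the 3 values shown sit.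

Compound 4 `CCCCCCCCCC(CCO)n1cnc2c(N)nc(Cl)nc21` is not yet measured. It differs from compound 3 by chloro in place of hydrogen on an aromatic carbon, the same kind of change as that from compound 2 to compound 1, though the place differs: in compound 1 the chloro sits next to the ring nitrogen, ortho to a fused ring, meta to a fused ring and opposite the ring nitrogen, whereas in compound 4 it sits between two ring nitrogen atoms, meta to a fused ring, meta to an amino group (1 heavy atom) and para to a fused ring. Within the data shown here, the one measured example of this kind of change gives no readable size, so the expectation rests on compound 3 alone, whose 10500 nM anchors it. The expected step is small: a 1.3-fold lower number from compound 3 to compound 4 (0.12 log units; within the scatter). Compound 4 is expected to give about 8000 nM in this assay. For compound 4 a range from 2500 nM to 30000 nM is expected.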

Compound 4, half-maximal inhibitory concentration: 14800 nM
Compound 4: middle estimate off by 1.9-fold (0.27 log units), on the low side; low and high end bracket the measured number.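

In this assay the new step is a 1.4-fold higher number from compound 3 to compound 4 (0.15 log units; within the scatter), so on the core of compound 3, chloro in place of hydrogen on an aromatic carbon between two ring nitrogen atoms cannot be told apart from leaving the hydrogen there. The same kind of change on the core of compound 2 cannot be read, because compound 1 and compound 2 both stand at a limit rather than at a number: the limit of > 50000 nM in this assay, at which 2 of the 4 values shown sit. There is thus no second size to set against this one, and the chloro also sits at a different place in the two pairs, so nothing here shows whether the change carries over from one core to the other.

Still open, on these data alone, is whether a bromo group or an amine at the same place in compound 4 would read differently from chloro. Also open, as far as these compounds go, is whether the chloro of compound 1 would give a readable step on a core bearing the longer chain of compound 3.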